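The compounds below may be only part of what the source reports. "The series", "measured", "known", "first", "only" and "open" are said of these compounds alone.

The measured compounds are compound 1 `O=C(/C=C/c1ccc2c(c1)B(O)OC2)c1ccccc1` with 6100 nM, compound 2 `COc1ccccc1C(=O)/C=C/c1ccc2c(c1)B(O)OC2` with 5000 nM, and compound 3 `COc1ccc(C(=O)/C=C/c2ccc3c(c2)B(O)OC3)cc1OC` with 12200 nM, all in a functional assay on HCT-116 cells (Homo sapiens) for cytotoxicity, read by MTT assay, with a stated time of 48 h; a higher number here means a weaker inhibitor, a lower number a stronger inhibitor.

From compound 1 to compound 2 the change is methoxy in place of hydrogen on an aromatic carbon, and the step is a 1.2-fold lower number from compound 1 to compound 2 (0.09 log units; within the scatter). Compound 4 `COc1cc(C(=O)/C=C/c2ccc3c(c2)B(O)OC3)cc(OC)c1OC` is not yet measured; it differs from compound 3 by methoxy in place of hydrogen on an aromatic carbon. This is the same kind of change, though the surroundings differ: in compound 2 the entering group sits ortho to a large group, whereas in compound 4 it sits ortho to a methoxy group, meta to a large group and meta to a methoxy group. The difference between the cores of compound 1 and compound 3 is not broken down here.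

Because the earlier step was a 1.2-fold lower number from compound 1 to compound 2 (0.09 log units; within the scatter), a step of similar size, a 1.2-fold lower number from compound 3 to compound 4 (0.09 log units; within the scatter), is expected in this assay. Compound 4 is therefore estimated at 10000 nM, with a range from 4000 nM to 25000 nM.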

Compound 4, half-maximal inhibitory concentration: 7900 nM
Beside the measured number, compound 4's estimate is 1.3-fold (0.10 log units) above it; the measured number falls inside the stated range.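

In this assay, methoxy in place of hydrogen on an aromatic carbon gives a 1.5-fold lower number from compound 3 to compound 4 (0.19 log units; within the scatter), and set beside the earlier step the two do not differ: the same change on two cores in this assay, a 1.2-fold lower number (0.09 log units; within the scatter) from compound 1 to compound 2 and a 1.5-fold lower number (0.19 log units; within the scatter) from compound 3 to compound 4, 1.3-fold (0.10 log units) apart, within the scatter of two such steps. Within these compounds, then, the change carries from the core of compound 1 to the core of compound 3 without a difference that can be told apart. Since each step is itself within the scatter, this does not show that methoxy has a real effect on either core, or that the agreement would hold on any other core.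

The compounds shown vary only by methoxy groups, so what an amine, a carboxylic acid or a longer chain such as butoxy would do remains open. Going by these compounds, whether the steps would look the same on other cells also remains open.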